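Working notes on a small cytotoxicity series

This account rests on a few compounds, and the source may have more. Where it says the series, first, only, none or still open, it means among the compounds named here.

Measured so far:
compound 1 `C/C(=N\NC(=O)c1ccc(-c2ccccc2)cc1)c1ccccc1O`: limit only, > 100000 nM
compound 2 `C/C(=N\NC(=O)c1cnccn1)c1ccccc1O`: 41200 nM
compound 3 `CC/C(=N\NC(=O)c1ccc(-c2ccccc2)cc1)c1ccccc1O`: limit only, > 100000 nM

In a toxicity assay (H9c2 cells) for cytotoxicity, with Rattus norvegicus as the target, read by neutral red uptake, with a stated time of 72 h (a higher number here means a weaker inhibitor, a lower number a stronger inhibitor), compound 1 gives > 100000 nM, which is a limit of the assay and not a number. Compound 3 likewise gives only a limit, > 100000 nM. Going by the values given here, compound 2 gives 41200 nM, the single number in the set. The difference between the cores of compound 1 and compound 2 is not broken down here.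

The change from compound 1 to compound 3 is methyl in place of hydrogen on a saturated chain carbon bound to a carbon with a double bond to nitrogen. Its size, a step that the two limits leave unreadable from compound 1 to compound 3, cannot be read because the limit of > 100000 nM in this assay, at which 2 of the 3 values shown sit, covers both ends of the pair.

Compound 4 `CC/C(=N\NC(=O)c1cnccn1)c1ccccc1O` differs from compound 2 by the same change, (methyl in place of hydrogen on a saturated chain carbon bound to a carbon with a double bond to nitrogen). Since the measured pair leaves the step unreadable, the expectation for compound 4 rests on compound 2 alone, at 41200 nM in this assay. The step of a 1.1-fold higher number from compound 2 to compound 4 (0.04 log units; within the scatter) is expected to stay within the usual scatter. Compound 4 is therefore estimated at 45000 nM, with a likely range from 20000 nM to 100000 nM.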

Compound 4, half-maximal inhibitory concentration: > 100000 nM
Compound 4: no number, only a limit (the forecaster's own chance of this, stated with the estimate: 25%); middle value at least 2.2-fold (0.34 log units) away from the limit.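

In this assay, methyl in place of hydrogen on a saturated chain carbon bound to a carbon with a double bond to nitrogen gives an at least 2.4-fold higher number from compound 2 to compound 4 (0.38 log units; beyond the scatter), so on the core of compound 2 the change moves the reading beyond the scatter. Compound 4 gives > 100000 nM, which is a limit of the assay and not a number. The same change on the core of compound 1 cannot be read, so the series does not show whether the step carries over from one core to the other, or with what size, because both ends of that pair rest on a single limit: the limit of > 100000 nM in this assay, at which 3 of the 4 values shown sit.

The compounds shown leave open how far the step on the core of compound 2 actually reaches, since only its lower bound can be read. They also leave open what a longer chain such as propyl, or an amine or a carboxylic acid, would give on that same saturated chain carbon.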